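Chloro for Bromo on the Para-Substituted Phenyl Ring

A few compounds are considered here, and "the series" means these few. Any claim that something is new, unique, unknown or untested is made for them only; others in the source may bear on it.

Measured compounds:
Compound 1, `O=C1C2ON=C(c3cn(-c4ccccc4)nc3-c3ccccc3)C2C(=O)N1c1ccccc1`: 47.4%
Compound 2, `O=C1C2ON=C(c3cn(-c4ccccc4)nc3-c3ccc(Br)cc3)C2C(=O)N1c1ccccc1`: 49%
Compound 3, `CN1C(=O)C2ON=C(c3cn(-c4ccccc4)nc3-c3ccc(Br)cc3)C2C1=O`: 40.4%

In a functional assay on the whole organism (Abdomen, strain Swiss albino) with Mus musculus as the target, with stated times of 10 min and 5 min, at a dose of 30 mg/kg by the oral route (on this read-out lower numbers stand for a weaker effect and higher numbers for a stronger effect at the one dose given), compound 2 gives 49%, the highest of the three numbers, yet its neighbours lie close: the step of a number 1.6 percentage points higher from compound 1 to compound 2 (within the scatter) and the step of a number 8.6 percentage points lower from compound 2 to compound 3 (within the scatter) are both within the scatter, so the three measured compounds cannot be told apart on this read-out.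

Compound 4, `O=C1C2ON=C(c3cn(-c4ccccc4)nc3-c3ccc(Cl)cc3)C2C(=O)N1c1ccccc1`, has not been measured. It differs from compound 2 in one place: chloro in place of bromo on an aromatic carbon. Of the measured steps, only a number 1.6 percentage points higher from compound 1 to compound 2 (within the scatter) touches the same aromatic carbon, and that step, from no halogen at all to bromo, stayed within the scatter. The step of a number 8.6 percentage points lower from compound 2 to compound 3 (within the scatter) concerns the amide-type nitrogen and says nothing about this position. Swapping one halogen for another is a smaller change than adding one, so no step beyond the scatter is expected in this assay; the expected step is a number 2 percentage points lower from compound 2 to compound 4 (within the scatter).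

Compound 4 is therefore estimated at 47%, between 38% and 56%.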

Compound 4, a percentage reported as activity, at one dose (the size of the read-out at that dose, not a potency): 43.2%
The estimate for compound 4 lay 3.8 percentage points above the measured number; the range from low to high includes it.
By their numbers in this assay, from the lowest: compounds 3, 4, 1 and 2 (each within the scatter of the next).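

In this assay chloro in place of bromo on this aromatic carbon gives a number 5.8 percentage points lower from compound 2 to compound 4 (within the scatter) and chloro in place of hydrogen gives a number 4.2 percentage points lower from compound 1 to compound 4 (within the scatter) on the same read-out. Where the earlier compounds compared only hydrogen with bromo at this carbon, hydrogen, bromo and chloro now all lie within the scatter of one another, so none of the three can be told apart here. Nothing available offers a reason for these numbers.

The compounds shown leave open whether any other group on this carbon, such as an amine, a carboxylic acid or a methoxy group, would separate from these three. They also leave open how chloro reads with methyl in place of phenyl on the amide-type nitrogen, the pairing that compound 3 carries with bromo.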